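A Phenyl Added Where Compound 1 Carries Hydrogen

This account rests on a few compounds, and the source may have more. Where it says the series, first, only, none or still open, it means among the compounds named here.

Compound 1 `O=C(O)Cc1sc(Cc2ccccc2)nc1-c1ccc(Cl)cc1` is one of two measured members of a shared core. In an in vitro functional assay on HEK285-7 cells for antagonist activity at prostaglandin D2 receptor 2 (Homo sapiens), read by BRET and beta-arrestin recruitment (on this read-out higher numbers stand for larger maximal responses and lower numbers for smaller maximal responses), compound 1 gives > 70%, and that value is a limit of the assay rather than a number. Compound 2 `O=C(O)Cc1sc(Cc2ccccc2)nc1-c1ccc(F)cc1` carries fluoro in place of chloro on an aromatic carbon, and in this assay compound 2 gives 30%. Among the compounds with values here, the one measured step is a number at least 40 percentage points lower from compound 1 to compound 2 (beyond the scatter), read against (the limit of > 70% in this assay, at which 1 of the 2 values shown sits).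

Compound 3 `O=C(O)Cc1sc(Cc2ccccc2-c2ccccc2)nc1-c1ccc(Cl)cc1` differs from compound 1 by phenyl in place of hydrogen on an aromatic carbon. The measured step concerns a different part of the molecule, so it offers no direct guidance for this change, and compound 1 itself stands only at a limit. The expectation is therefore a step that the limit leaves unreadable from compound 1 to compound 3, none beyond the scatter. Compound 3 is expected to reach 75% in this assay, with a range from 45% to 100%.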

Compound 3, largest response reached (reported as efficacy), in percent of the reference or control that the assay uses: > 70%
Compound 3 ended at the assay's limit; the forecaster's own chance of this, stated with the estimate: 40%; the middle value does not contradict the limit.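

Compound 1 and compound 3 both stand at a limit in this assay, so no step between them can be read: the limit of > 70% in this assay, at which 2 of the 3 values shown sit.

The compounds shown leave open whether phenyl in place of hydrogen changes the maximal response at all, and if so, by how much.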